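This account rests on a few compounds, and the source may have more. Where it says the series, first, only, none or still open, it means among the compounds named here.

Compounds measured in an assay on LtK cells with ATP-sensitive inward rectifier potassium channel 11 (Homo sapiens) as the target; on this read-out lower numbers stand for an effect already at smaller amounts and higher numbers for an effect only at larger amounts of compound:
compound 1 `CC(=O)Nc1c(C(O)(C(F)(F)F)C(F)(F)F)ccc2ccccc12` gives 18 nM;
compound 2 `O=C(NCCCCCCCl)Nc1c(C(O)(C(F)(F)F)C(F)(F)F)ccc2ccccc12` gives 4840 nM;
compound 3 `O=C(Nc1c(C(O)(C(F)(F)F)C(F)(F)F)ccc2ccccc12)c1ccc(Br)cc1` gives 47 nM.

Compound 3 stands second highest of the three numbers in this assay, apart from compound 1 by a modest step and apart from compound 2 by a large one. Compound 4 `O=C(Nc1c(C(O)(C(F)(F)F)C(F)(F)F)ccc2ccccc12)c1cc(Cl)cc(Cl)c1` differs from compound 3 in one place: 3,5-dichlorophenyl in place of 4-bromophenyl on a carbonyl carbon. Among the measured compounds shown here, the steps that bear on it are the aryl-for-methyl exchange, a 2.6-fold higher number from compound 1 to compound 3 (0.42 log units; beyond the scatter), and the aryl-for-urea exchange, a 100-fold lower number from compound 2 to compound 3 (2.01 log units; beyond the scatter); both keep or reach an aryl amide, so this swap of one halogenated phenyl for another is expected to move the number little, if at all, in this assay. Compound 4 is therefore estimated at 60 nM (range 20 nM to 200 nM), a step of a 1.3-fold higher number from compound 3 to compound 4 (0.11 log units; within the scatter) that is expected to stay within the scatter.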

Compound 4, half-maximal effective concentration: 306 nM
Estimate against measurement, compound 4: 5.1-fold (0.71 log units) below; the whole stated range lies below it.
By their numbers in this assay, from the lowest: compound 1; then compound 3; then compound 4; then compound 2.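

In this assay the choice of halogenated phenyl on the carbonyl carbon clearly matters, with a 6.5-fold higher number from compound 3 to compound 4 (0.81 log units; beyond the scatter) on going from 4-bromophenyl to 3,5-dichlorophenyl. The exchange for methyl, modest with 4-bromophenyl, becomes a 17-fold higher number from compound 1 to compound 4 (1.23 log units; beyond the scatter) with 3,5-dichlorophenyl, and the exchange for (6-chlorohexyl)amino now gives only a 16-fold lower number from compound 2 to compound 4 (1.20 log units; beyond the scatter) in place of the larger step seen with 4-bromophenyl. No measurement available here accounts for this difference. From the compounds shown here alone, what an unsubstituted phenyl, 4-chlorophenyl or 3,5-dibromophenyl would give on the same carbonyl carbon remains open, so the change of halogen and the change of substitution pattern cannot yet be separated.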